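Replacing 2,3-dihydroxyphenyl with 2-(difluoromethoxy)phenyl: what to expect

A few compounds are considered here, and "the series" means these few. Any claim that something is new, unique, unknown or untested is made for them only; others in the source may bear on it.

Among the measured compounds shown here, in a functional assay on G-361 cells (Homo sapiens) for antiproliferative activity, with a stated time of 72 h (on this read-out lower numbers stand for stronger inhibition and higher numbers for weaker inhibition), compound 3 `OC[C@H]1O[C@@H](n2cnc3c(NCc4cccc(O)c4O)ncnc32)[C@H](O)[C@@H]1O` gives 16900 nM, the only true number among the measured compounds. Compound 1 `OC[C@H]1O[C@@H](n2cnc3c(NCc4ccc(Br)cc4)ncnc32)[C@H](O)[C@@H]1O` reads > 166000 nM, which is a limit of the assay and not a number. Compound 2 `OC[C@H]1O[C@@H](n2cnc3c(NCc4ccc(F)c(Cl)c4)ncnc32)[C@H](O)[C@@H]1O` reads > 166000 nM, which is also a limit. Compound 3 therefore stands apart from the limit of > 166000 nM in this assay, at which 2 of the 3 values shown sit.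

Compound 4 `OC[C@H]1O[C@@H](n2cnc3c(NCc4ccccc4OC(F)F)ncnc32)[C@H](O)[C@@H]1O` has not yet been measured. It differs from compound 3 as follows: 2-(difluoromethoxy)phenyl in place of 2,3-dihydroxyphenyl on a saturated chain carbon bound to a nitrogen on an aromatic ring. Like compound 1 and compound 2, compound 4 carries halogen and no hydroxyl on its phenyl ring. For the measured compounds named here, two measured steps bear on this change: an at least 9.8-fold lower number from compound 1 to compound 3 (0.99 log units; beyond the scatter) and an at least 9.8-fold lower number from compound 2 to compound 3 (0.99 log units; beyond the scatter). Both lead towards the 2,3-dihydroxyphenyl group, whereas this change leads away from it, so a higher number is expected in this assay. The expected size is a 6.5-fold higher number from compound 3 to compound 4 (0.81 log units; beyond the scatter), which would mean weaker inhibition. The estimate for compound 4 is 110000 nM, with an expected range from 35000 nM to 166000 nM, and the assay may report only a limit.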

Compound 4, half-maximal inhibitory concentration: > 166000 nM
Compound 4: no number, only a limit (the forecaster's own chance of this, stated with the estimate: 60%); middle value at least 1.5-fold (0.17 log units) away from the limit.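

In this assay, exchanging 2,3-dihydroxyphenyl for 2-(difluoromethoxy)phenyl gives an at least 9.8-fold higher number from compound 3 to compound 4 (0.99 log units; beyond the scatter). The earlier steps replaced the hydroxyl groups with ring halogens, whereas this group keeps an oxygen on the phenyl ring and has its fluorines on the added carbon, yet the reading is again only a limit of the assay: the limit of > 166000 nM in this assay, at which 3 of the 4 values shown sit. Among the compounds shown, compound 3 alone gives a true number, and the steps from compound 1 and compound 2 to the new compound cannot be read, as both ends are limits.

From the compounds shown here alone, it remains open whether both hydroxyl groups are needed, which a phenyl ring with a single hydroxyl group could test. Also open, going by these compounds, is whether methoxy groups or an amine in their place would give a measurable number.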